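Swapping 6-hydroxyhexyl for 3,4-dihydroxyphenyl in compound 1

A few compounds are considered here, and "the series" means these few. Any claim that something is new, unique, unknown or untested is made for them only; others in the source may bear on it.

Compound 1 `O=C(OCCCCCCCCO)OCCc1ccc(O)c(O)c1`: > 50000 nM
Compound 2 `CCCCCCCCCCCCCCOC(=O)OCCc1ccc(O)c(O)c1`: 9100 nM
Compound 3 `CCCCCCCCCCCCCCCCOC(=O)OCCc1ccc(O)c(O)c1`: "not determined" (no result reported)

In an ADME assay on MRC5 cells (Homo sapiens) for inhibition, read by MTT assay, with a stated time of 72 h (on this read-out lower numbers stand for stronger inhibition and higher numbers for weaker inhibition), compound 1 gives > 50000 nM, which is a limit and not a number. Compound 4 `O=C(OCCc1ccc(O)c(O)c1)OCCc1ccc(O)c(O)c1` keeps the core of compound 1 but carries 3,4-dihydroxyphenyl in place of 6-hydroxyhexyl on a saturated chain carbon, two bonds along the chain from an oxygen next to a carbonyl group. For the measured compounds named here, only one measured step bears on this change, and it is indirect: hexyl in place of hydroxy on the chain gave an at least 5.4-fold lower number from compound 1 to compound 2 (0.73 log units; beyond the scatter). Compound 4 gains no such long saturated chain, so the drop of an at least 5.4-fold lower number from compound 1 to compound 2 (0.73 log units; beyond the scatter) is not expected to recur. The expected change is small: a number no higher from compound 1 to compound 4 (the limit leaves the size open). For compound 4 the estimated value is 50000 nM, with an expected range of 15000 nM to 150000 nM.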

Compound 4, half-maximal inhibitory concentration: > 50000 nM
Compound 4 was reported as a limit (the forecaster's own chance of this, stated with the estimate: 65%); the middle value lies on the limit itself.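

No step can be read from compound 1 to compound 4, because both results are limits and not numbers: the limit of > 50000 nM in this assay, at which 2 of the 4 values shown sit.

The compounds shown leave open how strongly compound 1 and compound 4 actually inhibit, and whether swapping 6-hydroxyhexyl for 3,4-dihydroxyphenyl changes that at all.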